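Mirror-image pair in the shared core series

The source may hold more compounds than are shown below. What is called first, only, known or untested is meant among the compounds shown, and "the series" means these compounds.

Compound 3 `Cc1cc(N2C[C@@H]3CCNC[C@@H]32)cnc1Cl` gives the lowest number of the three measured in a functional assay on HEK293 cells for agonist activity at Neuronal acetylcholine receptor; alpha4/beta2 (Homo sapiens), read by FLIPR (on this read-out lower numbers stand for an effect already at smaller amounts and higher numbers for an effect only at larger amounts of compound), at 76.1 nM; compound 2 `Clc1cc(N2C[C@H]3CCNC[C@H]32)cnc1Cl` gives 176 nM and compound 1 `Clc1ccc(N2C[C@H]3CCNC[C@H]32)cn1` gives 216 nM, both beyond the scatter from compound 3. Among the compounds with values here, the only single-point step measured so far, a 1.2-fold lower number from compound 1 to compound 2 (0.09 log units; within the scatter), concerns a chloro in place of hydrogen on an aromatic carbon and says nothing about configuration. Compound 4 `Cc1cc(N2C[C@H]3CCNC[C@H]32)cnc1Cl` differs from compound 3 as follows: the two compounds have the same atoms and bonds and differ only in configuration as drawn: 2 of 2 stereo elements differ (all stereocentres are inverted: mirror images); a stereocentre at a saturated ring carbon is drawn S in compound 3 and R in compound 4; a stereocentre at a saturated ring carbon is drawn R in compound 3 and S in compound 4. Within the data shown here, no measured step covers a mirror-image inversion, so the size and direction of the change in this assay cannot be read from the series; compounds 1 and 2 carry the configuration drawn for compound 4 and give numbers higher than compound 3, but they also differ in substituents, so they offer no clean comparison. For the mirror image a higher number is regarded as somewhat more probable than a lower one, and the expected step is a 3.3-fold higher number from compound 3 to compound 4 (0.52 log units; beyond the scatter). Compound 4 is therefore estimated at 250 nM, with a wide range from 40 nM to 2000 nM.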

Compound 4, half-maximal effective concentration: 134 nM
Beside the measured number, compound 4's estimate is 1.9-fold (0.27 log units) above it; the range from low to high includes it.
By their numbers in this assay, from the lowest: compounds 3, 4, 2 and 1 (each within the scatter of the next, the first and the last beyond it).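

In this assay, within the data shown here, inverting both stereocentres gives a 1.8-fold higher number from compound 3 to compound 4 (0.25 log units; within the scatter), so the only mirror-image pair is not separated beyond the scatter: the fact that compounds 3 and 4 differ only in the configuration as drawn. Within the configuration drawn for compound 4, methyl in place of chloro on the aromatic carbon gives a 1.3-fold lower number from compound 2 to compound 4 (0.12 log units; within the scatter), and methyl in place of hydrogen gives a 1.6-fold lower number from compound 1 to compound 4 (0.21 log units; within the scatter). With this configuration, hydrogen, chloro and methyl at that carbon therefore give numbers within the scatter of one another in compounds 1, 2 and 4.

The compounds shown leave open whether the mirror-image step stays this small when hydrogen or chloro replaces the methyl. They also leave open how a methoxy group or a nitrile on that carbon would read in this assay.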